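Porcupine inhibitor series: benzothiazolyl amides, methoxy to chloro

The source may hold more compounds than are shown below. What is called first, only, known or untested is meant among the compounds shown, and "the series" means these compounds.

Measured compounds:
- compound 1, `COc1ccc(-n2nc(C(=O)NCC(=O)Nc3nc4ccc(Cl)cc4s3)c3ccccc3c2=O)cc1`: 15 nM
- compound 2, `COc1ccc(-n2c(SCC(=O)Nc3nc4ccc(OC)cc4s3)nc3c(c2=O)SCC3)cc1`: 120 nM
- compound 3, `COc1ccc(-n2nc(C(=O)NCC(=O)Nc3nc4ccc(OC)cc4s3)c3ccccc3c2=O)cc1`: 60 nM

All three were measured in an assay on L cells for inhibition of Protein-serine O-palmitoleoyltransferase porcupine (Mus musculus), read by reporter gene assay, with a stated time of 24 h; a higher number here means that more compound is needed for the effect, a lower number that less compound is needed. Compound 1 gives 15 nM, compound 3 gives 60 nM, and compound 2 gives 120 nM in this assay.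

Compound 1 and compound 3 share one core and differ only at the benzothiazole: chloro in place of methoxy on an aromatic carbon. That change gave a 4.0-fold lower number from compound 3 to compound 1 (0.60 log units; beyond the scatter).

Compound 2 carries a different core from compound 3; the difference between the two cores is not broken down here. Compound 2 and compound 3 both carry the methoxy-substituted benzothiazole, and their values in this assay lie within the usual scatter of each other, so no order is read from them. Compound 1 stands well apart from compound 2 in this assay.

Compound 4, `COc1ccc(-n2c(SCC(=O)Nc3nc4ccc(Cl)cc4s3)nc3c(c2=O)SCC3)cc1`, is not yet measured. It differs from compound 2 by chloro in place of methoxy on an aromatic carbon. This is the same change as from compound 3 to compound 1, on the same place of the benzothiazole, but on the other core.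

For compound 4 in this assay a step of about a 3.4-fold lower number from compound 2 to compound 4 (0.54 log units; beyond the scatter) is expected, resting on the step of a 4.0-fold lower number from compound 3 to compound 1 (0.60 log units; beyond the scatter) seen with the first core. Since that comparison rests on a single pair and the core is different, the expectation carries a broad range. Compound 4 is estimated at 35 nM (range 15 nM to 90 nM).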

Compound 4, half-maximal effective concentration: 35 nM
Compound 4: the middle estimate sits on the measured number at the digits printed; the measured number falls inside the stated range.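

In this assay, 6-chloro-1,3-benzothiazol-2-yl in place of 6-methoxy-1,3-benzothiazol-2-yl on the core of compound 2 gives a 3.4-fold lower number from compound 2 to compound 4 (0.54 log units; beyond the scatter). The step carries over from one core to the other with no difference that can be read: the same change on two cores in this assay, a 4.0-fold lower number (0.60 log units; beyond the scatter) from compound 3 to compound 1 and a 3.4-fold lower number (0.54 log units; beyond the scatter) from compound 2 to compound 4, 1.2-fold (0.07 log units) apart, within the scatter of two such steps This agreement rests on a single pair for each core, so it holds for this one change on these two cores only; it gives no reason for the step and no rule for a further core or for any other group.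

Still open is whether other groups in the same place on the benzothiazole, such as fluoro, bromo, trifluoromethyl or nitrile, would give matching steps on both cores, as only methoxy and chloro are shown there. Also open, as far as these compounds go, is whether a change elsewhere, for instance an amine or a carboxylic acid in place of the methoxy outside the benzothiazole, would carry from one core to the other in the same way.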